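Halogen swap on a cinnamate ester: bromo to fluoro

The source may report more compounds than this note shows. Statements on the series, on what has been measured and on what is new or still open speak of the compounds shown alone.

Two esters built on a shared core have been run so far in a functional assay on the whole organism (strain Kunming) with Mus musculus as the target, with a stated time of 0.5 h, at a dose of 100 mg/kg by the intraperitoneal route; a higher number here means a weaker effect of the compound at the dose given, a lower number a stronger effect. Compound 1 `COc1cc(OC)c(OC)cc1/C=C/COC(=O)/C=C/c1cc(OC)c(OC)c(OC)c1OC` gives 100% in this assay. Compound 2 `COc1cc(OC)c(OC)cc1/C=C/COC(=O)/C=C/c1ccc(Br)cc1` gives 100% in this assay, and so compound 2 stands level with compound 1 at the digits reported, the two values lying within the scatter of each other. Among the compounds with values here, no step between measured compounds is available that would show what a single change on the aromatic ring does to this read-out.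

Compound 3 `COc1cc(OC)c(OC)cc1/C=C/COC(=O)/C=C/c1ccc(F)cc1` has not yet been measured. It differs from compound 2 in one place: fluoro in place of bromo on an aromatic carbon. The change sits on an aromatic carbon of a six-membered aromatic ring of carbon only, para to a large group, and the halogen on that ring is the only thing that moves.

Since compound 1 and compound 2 give the same read-out despite carrying quite different aromatic ends, compound 3 is expected to sit at about the same level, with a step of a number 4 percentage points lower from compound 2 to compound 3 (within the scatter) that is estimated to stay within the scatter. For compound 3 the estimated value in this assay is 96%, within a range from 80% to 100%.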

Compound 3, a percentage reported as activity, at one dose (the size of the read-out at that dose, not a potency): 100%
Estimate against measurement, compound 3: 4 percentage points below, and the stated range covers the measured number.
By their numbers in this assay, from the lowest: compounds 1, 2 and 3 (each within the scatter of the next).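

In this assay, within the data shown here, the exchange of bromo for fluoro on an aromatic carbon, para to a large group, gives no change at the digits printed from compound 2 to compound 3 (within the scatter) and so provides the first reading of a single change at this position. At the one dose and time used, the read-out does not separate the 4-bromophenyl ester from the 4-fluorophenyl ester, so this halogen swap offers no handle on the effect of the compounds in the whole animal. Nothing at hand bears on why the two halogens read alike.

As far as these compounds go, whether an amine, a carboxylic acid or a nitrile on that same aromatic carbon would bring the number down in this assay remains open, as does the reading of a plain phenyl ring with hydrogen in place of the halogen. Also open, from the compounds shown here alone, is whether any change away from this ring, such as an amide in place of the ester linkage or a saturated chain in place of the double bond, would move the read-out at all.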